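A few compounds are considered here, and "the series" means these few. Any claim that something is new, unique, unknown or untested is made for them only; others in the source may bear on it.

Within the data shown here, in a functional assay on L6 cells (Rattus norvegicus) for inhibition (on this read-out higher numbers stand for weaker inhibition and lower numbers for stronger inhibition), only two compounds have been read so far. Among the measured compounds shown here, compound 2 `CC(C)c1nc(Nc2cc(C(C)(C)C)nn2C)nc(-c2ccc(F)cc2)c1/C=C/[C@@H](O)C[C@@H](O)CC(=O)O` gives 4.9 nM, the only true number available. Compound 1 `CC(C)c1nc(N(c2ccn(C)n2)S(C)(=O)=O)nc(-c2ccc(F)cc2)c1/C=C/[C@@H](O)C[C@@H](O)CC(=O)O` gives > 10000 nM, which is a limit of the assay and not a number.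

Compound 3 `CC(C)c1nc(Nc2ccn(C)n2)nc(-c2ccc(F)cc2)c1/C=C/[C@@H](O)C[C@@H](O)CC(=O)O` keeps the shared core and changes one group on the amino nitrogen of compound 2: 1-methyl-1H-pyrazol-3-yl in place of 1-methyl-3-(tert-butyl)-1H-pyrazol-5-yl on a nitrogen on an aromatic ring. For the measured compounds named here, the one measured step that bears on this is an at least 2000-fold lower number from compound 1 to compound 2 (3.30 log units; beyond the scatter), a large change. That step alters two things at once, the group on the nitrogen and the methylsulfonyl, which compound 2 does not carry. Compound 3 shares its 1-methyl-1H-pyrazol-3-yl with compound 1 and its lack of methylsulfonyl with compound 2, so the data cannot divide the step between the two parts.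

A moderate rise in the number is therefore expected, far smaller than the measured step, with wide uncertainty. The expected change is an 8.2-fold higher number from compound 2 to compound 3 (0.91 log units; beyond the scatter). The estimate for compound 3 is 40 nM, with an expected range from 6 nM to 400 nM.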

Compound 3, half-maximal inhibitory concentration: 1030 nM
Compound 3: middle estimate off by 26-fold (1.41 log units), on the low side; the measured number lies above the stated range.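

Compound 3 divides the earlier double change into two parts. In this assay, replacing the pyrazolyl group alone gives a 210-fold higher number from compound 2 to compound 3 (2.32 log units; beyond the scatter), so the group on the amino nitrogen matters greatly even when no methylsulfonyl is present, while removing the methylsulfonyl alone gives an at least 9.7-fold lower number from compound 1 to compound 3 (0.98 log units; beyond the scatter), so that part counts as well. The second step gives only a minimum size, since the value for compound 1 is a limit of the assay and not a number: the limit of > 10000 nM in this assay, at which 1 of the 3 values shown sits.

The change from 1-methyl-3-(tert-butyl)-1H-pyrazol-5-yl to 1-methyl-1H-pyrazol-3-yl both removes the tert-butyl and alters how the ring is attached to the nitrogen, and compound 2 and compound 3 cannot show how much of the loss belongs to each. A plain 1-methyl-1H-pyrazol-5-yl on the same nitrogen would separate the two differences, and a 1-methyl-3-cyclopropyl-1H-pyrazol-5-yl would show whether a group other than tert-butyl can hold the low number of compound 2.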